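The source may hold more compounds than are shown below. What is called first, only, known or untested is meant among the compounds shown, and "the series" means these compounds.

Measured compounds in hand:

Compound 1, `COc1ccc(/C=C\c2cc(OC)c(OC)c(OC)c2)cc1OCc1ccc(CN2CCCCC2C(=O)O)cc1`, gives 3100 nM in a functional assay on HepG2 cells (Homo sapiens) for antiproliferative activity, read by CCK-8 assay, with a stated time of 48 h; a lower number here means a stronger inhibitor, a higher number a weaker inhibitor.
Compound 2, `COc1ccc(/C=C\c2cc(OC)c(OC)c(OC)c2)cc1OCc1ccc(CN2CCCCC2C(=O)NCCN)cc1`, gives 4800 nM in this assay.

Among the measured compounds shown here, compound 2 stands at the higher of the two numbers, and its only neighbour is compound 1. The step of a 1.5-fold higher number from compound 1 to compound 2 (0.19 log units; within the scatter) lies within the scatter, so the two compounds cannot be ordered against each other on these data.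

Compound 3, `COc1ccc(/C=C\c2cc(OC)c(OC)c(OC)c2)cc1OCc1ccc(CN2CCCCC2C(=O)NCCNC(=O)OC(C)(C)C)cc1`, has not yet been measured in this assay. It differs from compound 2 by tert-butoxycarbonyl in place of hydrogen on an amine nitrogen. For the measured compounds named here, no measured step touches this position: the single step available, a 1.5-fold higher number from compound 1 to compound 2 (0.19 log units; within the scatter), concerns the group on the carbonyl carbon, not the terminal amine nitrogen, and it was itself within the scatter. The data therefore give no direction for the change to the tert-butoxycarbonyl group, and the two numbers already in hand sit close together.

On that footing the step of a 1.1-fold lower number from compound 2 to compound 3 (0.03 log units; within the scatter) is expected to be small, most likely not beyond the scatter. Compound 3 is estimated to give 4500 nM in this assay, within a range of 1500 nM to 13000 nM.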

Compound 3, half-maximal inhibitory concentration: 1100 nM
For compound 3 the middle estimate is 4.1-fold (0.61 log units) above the measured one; the whole stated range lies above it.
By their numbers in this assay, from the lowest: compound 3; then compounds 1 and 2 (each within the scatter of the next).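

In this assay, among the compounds shown here, the terminal amine nitrogen of the 2-aminoethyl chain proves to be a place where a change can be read, since tert-butoxycarbonyl in place of hydrogen there gives the first step that lies beyond the scatter (a 4.4-fold lower number from compound 2 to compound 3 (0.64 log units; beyond the scatter)). The group on the carbonyl carbon now also separates from the free carboxylic acid, with (2-((tert-butoxycarbonyl)amino)ethyl)amino in place of hydroxy (a 2.8-fold lower number from compound 1 to compound 3 (0.45 log units; beyond the scatter)), whereas the unprotected (2-aminoethyl)amino group of compound 2 could not be ordered against compound 1, so the difference appears only with tert-butoxycarbonyl on the amine nitrogen. Nothing offered here accounts for why this change lowers the number.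

From the compounds shown here alone, it stays open whether the tert-butoxycarbonyl group as a whole matters or whether a smaller acyl group such as acetyl, or a simpler carbamate such as methoxycarbonyl, on the same nitrogen would do the same. The length of the chain is equally unsettled, as a propyl or butyl chain between the amide nitrogen and the carbamate would show whether the 2-carbon ethyl spacer matters.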